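Arylamine versus Benzylamine on a Shared Quinone Core

This account rests on a few compounds, and the source may have more. Where it says the series, first, only, none or still open, it means among the compounds named here.

Three compounds have been measured in a functional assay on MCF7 cells (Homo sapiens) for inhibition, read by sulforhodamine B assay; on this read-out higher numbers stand for weaker inhibition and lower numbers for stronger inhibition:
Compound 1, `Cc1ccc(NC2=CC(=O)c3c(nc4n3[C@H]3OC[C@@H](O)[C@H]3OC4)C2=O)cc1C`, gives 4950 nM.
Compound 2, `O=C1C(N2CCCCC2)=CC(=O)c2c1nc1n2[C@H]2OC[C@@H](O)[C@H]2OC1`, gives only a limit of the assay, > 8000 nM.
Compound 3, `O=C1C=C(NCc2ccccc2)C(=O)c2c1nc1n2[C@H]2OC[C@@H](O)[C@H]2OC1`, likewise gives only a limit of the assay, > 8000 nM.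

So compound 3 stands at the limit of > 8000 nM in this assay, at which 2 of the 3 values shown sit, with no number of its own. Compound 4, `CCOc1ccc(NC2=CC(=O)c3nc4n(c3C2=O)[C@H]2OC[C@@H](O)[C@H]2OC4)cc1`, differs from compound 3 in one place: 4-ethoxyphenyl in place of benzyl on an amine nitrogen. Within the data shown here, only one measured step exists, and it runs in a related direction: an at least 1.6-fold higher number from compound 1 to compound 2 (0.20 log units; that floor lies within the scatter), a step whose floor lies within the scatter. Compound 1 carries an aromatic ring directly on the amine nitrogen and gives a number, while compound 3, with a benzyl group there, gives only a limit. Compound 4 puts an aromatic ring directly on that nitrogen, as compound 1 does, so a number near that of compound 1 is expected, meaning a step of an at least 1.4-fold lower number from compound 3 to compound 4 (0.16 log units; that floor lies within the scatter). Compound 4 is therefore estimated at 5500 nM, between 2500 nM and 12000 nM, with a real chance that the assay again reports only a limit.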

Compound 4, half-maximal inhibitory concentration: 1430 nM
Estimate against measurement, compound 4: 3.8-fold (0.59 log units) above; the measured number lies below the stated range.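

In this assay, replacing benzyl with 4-ethoxyphenyl on the amine nitrogen gives an at least 5.5-fold lower number from compound 3 to compound 4 (0.74 log units; beyond the scatter), so inhibition is clearly stronger with the new group. Among these compounds, this is the first step here that lies beyond the usual scatter, which shows that the group on this nitrogen can change the read-out by a real margin. The true size of the step remains unknown because compound 3 has only a limit of the assay and no number of its own: the limit of > 8000 nM in this assay, at which 2 of the 4 values shown sit.

The change does two things at once: it puts the aromatic ring directly on the nitrogen and adds an ethoxy group, and the compounds shown cannot separate these two effects. Going by these compounds, it remains open what a plain phenyl group would give on this nitrogen, or a phenyl ring carrying an amine or a longer butoxy chain in place of the ethoxy group.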